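The source may report more compounds than this note shows. Statements on the series, on what has been measured and on what is new or still open speak of the compounds shown alone.

Working notes on the series. Compound 2 `COc1cc(/C=N/NC(=O)COc2cccc3ccccc23)cc(OC)c1OC` stands in an ADME assay on HEL cells (Homo sapiens) for cytotoxicity (a lower number here means that less compound is tolerated, a higher number that more compound is tolerated), at >= 20 ug/mL, which is a limit of the assay and not a number. Compound 3 `COc1ccc(/C=N/NC(=O)COc2cccc3ccccc23)cc1OC` also gives >= 20 ug/mL, again a limit. Compound 1 `COc1ccc(/C=N/NC(=O)COc2cccc3ccccc23)cc1O` gives a number, 100 ug/mL. Of the three values shown, two sit at the limit, (the limit of >= 20 ug/mL in this assay, at which 2 of the 3 values shown sit), so compound 2 is placed only by that limit and cannot be ordered against compound 3.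

The next compound, compound 4 `COc1cc(/C=N/NC(=O)COc2cccc3ccccc23)cc(OC)c1O`, differs from compound 2 as hydrogen in place of methyl on an oxygen on an aromatic ring.

For the measured compounds named here, two measured steps bear on it. The step that the limit leaves unreadable from compound 1 to compound 3 is the same kind of change in the opposite direction, and the step that the two limits leave unreadable from compound 2 to compound 3 touches the other methoxy of compound 2; neither yields a readable size. From the compounds shown here alone, nothing measured therefore points to a step beyond the scatter in either direction, and a step within the scatter is the working assumption, though a value near that of compound 1 100 ug/mL is also open.

Compound 4 is accordingly expected to show 50 ug/mL in this assay, between 20 ug/mL and 150 ug/mL. The expected step from compound 2 is a step that the limit leaves unreadable from compound 2 to compound 4.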

Compound 4, minimum cytotoxic concentration: 100 ug/mL
For compound 4 the middle estimate is 2.0-fold (0.30 log units) below the measured one, within the range that was stated.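

The step from compound 2 to compound 4 cannot be read, since compound 2 is placed only by a limit while compound 4 has a number: the limit of >= 20 ug/mL in this assay, at which 2 of the 4 values shown sit.

The compounds shown leave open whether the change from methoxy to hydroxy, in compound 2 to compound 4 or in compound 3 to compound 1, shifts the result in this assay at all.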